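This account rests on a few compounds, and the source may have more. Where it says the series, first, only, none or still open, it means among the compounds named here.

Measured so far in an ADME assay on the whole organism (Rattus norvegicus) for pharmacokinetics, using cassette dosing, at a dose of 1 mg/kg by the oral route; on this read-out higher numbers stand for higher oral bioavailability and lower numbers for lower oral bioavailability:
- compound 1 `C[C@@H](Cn1c(=O)[nH]/c(=N\c2ccc(Oc3ccc(F)cn3)cc2)n(Cc2ccc(Cl)cc2)c1=O)C(=O)O`: 82.4%
- compound 2 `CC(C)Oc1ccc(/N=c2\[nH]c(=O)n(C[C@H](C)C(=O)O)c(=O)n2Cc2ccc(Cl)cc2)cc1Cl`: 82.4%
- compound 3 `CC(C)Oc1ccc(/N=c2\[nH]c(=O)n(CC(C)(C)C(=O)O)c(=O)n2Cc2ccc(Cl)cc2)cc1Cl`: 85.3%

Among the compounds with values here, compound 1 gives 82.4%, the same number as compound 2, and its value lies within the usual scatter of the one for compound 3. The three compounds therefore cannot be told apart on this read-out.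

The next compound is compound 4 `C[C@@H](Cn1c(=O)[nH]/c(=N\c2ccc(Oc3ccnc(F)c3)cc2)n(Cc2ccc(Cl)cc2)c1=O)C(=O)O`, which has the same atoms as compound 1, joined differently: 2-fluoropyridin-4-yl in place of 5-fluoropyridin-2-yl on an oxygen on an aromatic ring. In plain terms, 2-fluoropyridin-4-yl stands in place of 5-fluoropyridin-2-yl on an oxygen on an aromatic ring.

Within the data shown here, only one measured step compares two compounds that differ in a single place: a number 2.9 percentage points higher from compound 2 to compound 3 (within the scatter). That step puts 1-carboxy-1-methylethyl in place of 1-carboxyethyl, so it concerns a different part of the molecule and bears on this change only indirectly. Among the measured compounds shown here, it shows that one small change elsewhere left this assay within the scatter, but no measured step tests a fluoropyridine swap. The data therefore give no reason to expect a change in a particular direction, although a slight drop from such high values would not be surprising.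

The expected step is a number 4.4 percentage points lower from compound 1 to compound 4 (within the scatter). Compound 4 is estimated at 78%, with an expected range of 60% to 93%.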

Compound 4, oral bioavailability: 43.2%
Estimate against measurement, compound 4: 34.8 percentage points above; the measured number lies below the stated range.
By their numbers in this assay, from the lowest: compound 4; then compounds 1, 2 and 3 (each within the scatter of the next).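

In this assay the group on the ether oxygen turns out to matter: 2-fluoropyridin-4-yl in place of 5-fluoropyridin-2-yl gives a number 39.2 percentage points lower from compound 1 to compound 4 (beyond the scatter). Within the data shown here, until now the only single-place comparison concerned the chain carrying the carboxylic acid and stayed within the scatter, so this is the first step to go beyond it, and it comes from a swap that keeps the same atoms and the same counts of donors and acceptors, changing only how they are joined. Nothing in the available data explains why this rearrangement has such a large effect.

Both the ring nitrogen and the fluorine sit differently in the two rings, so the compounds shown cannot say which of the two matters, or whether both do. Going by these compounds, a plain pyridin-4-yl without fluorine, a phenyl ring, or a chlorine or methoxy group in place of the fluorine on either pyridine would help separate these possibilities, and it also remains open whether the same swap would have a similar effect on the carboxylic acid chain of compound 3.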